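A few compounds are considered here, and "the series" means these few. Any claim that something is new, unique, unknown or untested is made for them only; others in the source may bear on it.

Measured so far:
Compound 1, `CC(C(=O)N1CCN(c2ccccc2)CC1)N1C(=O)CCC1=O`: 0%
Compound 2, `CC(C(=O)N1CCN(c2ccccc2C(F)(F)F)CC1)N1C(=O)CCC1=O`: 0%

In a functional assay on the whole organism (strain Swiss) with Mus musculus as the target, in the maximal electroshock model, with a stated time of 2 h, at a dose of 100 mg/kg by the intraperitoneal route (a higher number here means a stronger effect of the compound at the dose given, a lower number a weaker effect), compound 1 gives 0%, and it stands level with compound 2 at the digits shown. Compound 2 carries trifluoromethyl in place of hydrogen on an aromatic carbon of the phenyl, and in this assay compound 2 gives 0%. Within the data shown here, the one measured step, no change at the digits printed from compound 1 to compound 2 (within the scatter), therefore shows that putting a substituent onto the phenyl of this core did not move the read-out beyond the scatter.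

Compound 3, `CC(C(=O)N1CCN(c2cccc(F)c2)CC1)N1C(=O)CCC1=O`, has not yet been tested in this assay. It differs from compound 1 in a single place: fluoro in place of hydrogen on an aromatic carbon. Among the measured compounds shown here, the step from compound 1 to compound 2 is the only measured step that bears on this change, since it is likewise a substituent entering on an aromatic carbon of the phenyl, and it was flat. On that basis no change beyond the scatter is expected from compound 1 to compound 3, a step of no change at the digits printed from compound 1 to compound 3 (within the scatter). Compound 3 is accordingly estimated at 0%, with a range of 0% to 12%, pending the measurement.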

Compound 3, a percentage reported as activity, at one dose (the size of the read-out at that dose, not a potency): 0%
For compound 3 middle estimate and measured number coincide at the digits printed; measured number inside the range.
By their numbers in this assay, from the lowest: compounds 1, 2 and 3 (each within the scatter of the next).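

Replacing phenyl by 3-fluorophenyl, with one fluorine entering on an aromatic carbon meta to a large group, results in no change at the digits printed from compound 1 to compound 3 (within the scatter) in this assay at the dose given. Taken with no change at the digits printed from compound 1 to compound 2 (within the scatter) for trifluoromethyl, this makes two different substituents on the phenyl of the core of compound 1 that leave the read-out where it was, so the flat result no longer rests on a single group. Compound 1 itself gives 0% here, and neither fluoro nor trifluoromethyl lifts the read-out off that value. Nothing measured here bears on what lies behind this result.

The compounds shown leave open whether a group of another kind on the phenyl, such as an amine, a carboxylic acid or a methoxy group, would raise the read-out above that of compound 1, and whether fluoro on another carbon of the ring would do so. As far as these compounds go, it also remains open whether a change away from the phenyl, such as a longer chain in place of the methyl group of the shared core, would give any effect in this model.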